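Sulfide to sulfone on a triazolyl-bearing indole glyoxamide

The compounds below may be only part of what the source reports. "The series", "measured", "known", "first", "only" and "open" are said of these compounds alone.

Of the compounds shown here, two of a shared core have been measured in a functional assay on MT2 cells (Homo sapiens) for cytotoxicity, read by XTT assay, with a stated time of 3 days; on this read-out higher numbers stand for lower toxicity in this test and lower numbers for higher toxicity in this test. Compound 1 `COc1cnc(-c2ccncc2)c2[nH]cc(C(=O)C(=O)N3CCN(C(=O)c4ccccc4)CC3)c12` gives 6000 nM in this assay. Compound 2 `CCCSc1ncn(-c2ncc(OC)c3c(C(=O)C(=O)N4CCN(C(=O)c5ccccc5)CC4)c[nH]c23)n1` gives 7000 nM in this assay. Within the data shown here, the only change mapped between them is a 1.2-fold higher number from compound 1 to compound 2 (0.07 log units; within the scatter), so compound 2 holds the highest of the two numbers, yet its distance to compound 1 is within the scatter and no order between them can be read. Compound 3 `CCCS(=O)(=O)c1ncn(-c2ncc(OC)c3c(C(=O)C(=O)N4CCN(C(=O)c5ccccc5)CC4)c[nH]c23)n1` differs from compound 2 by propylsulfonyl in place of propylsulfanyl on an aromatic carbon. Among the measured compounds shown here, no measured step covers such an exchange, and the one step that exists, from a pyridin-4-yl to a triazolyl group, has nothing in common with it beyond its small size. The estimate for compound 3 therefore rests on the near-flat behaviour of the two measured values and is expected to be no change at the digits printed from compound 2 to compound 3 (within the scatter), that is, no step beyond the scatter. On this basis compound 3 is expected to give about 7000 nM, within a range from 3000 nM to 20000 nM.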

Compound 3, half-maximal cytotoxic concentration: 207000 nM
Beside the measured number, compound 3's estimate is 30-fold (1.47 log units) below it; measured number outside the range, above it.
By their numbers in this assay, from the lowest: compounds 1 and 2 (each within the scatter of the next); then compound 3.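

In this assay, among these compounds, the exchange of propylsulfanyl for propylsulfonyl on the aromatic carbon of the triazole ring gives a 30-fold higher number from compound 2 to compound 3 (1.47 log units; beyond the scatter) and is the first change at this position that can be read beyond the scatter. The earlier step from pyridin-4-yl to 3-(propylsulfanyl)-1H-1,2,4-triazol-1-yl had left the number within the scatter, whereas 3-(propylsulfonyl)-1H-1,2,4-triazol-1-yl in place of pyridin-4-yl gives a 35-fold higher number from compound 1 to compound 3 (1.54 log units; beyond the scatter) and so shows that the triazolyl group alone does not set the number here, while the two oxygen atoms on its sulfur do. Nothing available explains this large step.

From the compounds shown here alone, whether a sulfoxide, a methylsulfonyl group or a butylsulfonyl chain would give a similar number stays open. So does whether a sulfonamide or a carboxylic acid at this carbon would follow compound 3 or compound 2.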